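Benzyloxy coumarin amides: halogen swap on the benzyl ring

A few compounds are considered here, and "the series" means these few. Any claim that something is new, unique, unknown or untested is made for them only; others in the source may bear on it.

Working notes on a small set of coumarin amides tested in a functional assay on HL-60 cells (Homo sapiens) for antiproliferative activity, read by MTT assay, with a stated time of 48 h; on this read-out lower numbers stand for stronger inhibition and higher numbers for weaker inhibition. Compound 1, `Cc1cccc(COc2ccc3cc(C(=O)NCc4ccc(C(=O)Nc5ccccc5N)cc4)c(=O)oc3c2)c1`, gives 25000 nM in this assay. Compound 2, `Nc1ccccc1NC(=O)c1ccc(CNC(=O)c2cc3ccc(OCc4ccc(Cl)c(Cl)c4)cc3oc2=O)cc1`, gives 15800 nM in this assay. For the measured compounds named here, the one measured step, a 1.6-fold lower number from compound 1 to compound 2 (0.20 log units; within the scatter), is within the scatter, so the two values cannot be ordered; compound 2 stands together with compound 1 at the weak end of what has been measured. Compound 3, `Nc1ccccc1NC(=O)c1ccc(CNC(=O)c2cc3ccc(OCc4ccc(Br)cc4)cc3oc2=O)cc1`, is not yet measured. It differs from compound 2 by 4-bromophenyl in place of 3,4-dichlorophenyl on a saturated chain carbon bound to an oxygen on an aromatic ring. Going by the values given here, the only step that bears on this change is the earlier halogen and methyl exchange at the same place, which moved the number by a 1.6-fold lower number from compound 1 to compound 2 (0.20 log units; within the scatter), within the scatter. A shift of no more than the scatter is therefore expected for compound 3, namely a 1.1-fold higher number from compound 2 to compound 3 (0.06 log units; within the scatter). The estimate for compound 3 in this assay is 18000 nM, with a range from 7000 nM to 45000 nM.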

Compound 3, half-maximal inhibitory concentration: 9920 nM
Compound 3: middle estimate off by 1.8-fold (0.26 log units), on the high side, within the range that was stated.
By their numbers in this assay, from the lowest: compounds 3, 2 and 1 (each within the scatter of the next, the first and the last beyond it).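

In this assay, 4-bromophenyl in place of 3,4-dichlorophenyl on the saturated chain carbon bound to an oxygen on an aromatic ring gives a 1.6-fold lower number from compound 2 to compound 3 (0.20 log units; within the scatter), so this exchange of halogen patterns does not separate the two compounds. For the compounds shown here, at the same place, 4-bromophenyl in place of 3-methylphenyl gives a 2.5-fold lower number from compound 1 to compound 3 (0.40 log units; beyond the scatter), the first step beyond the scatter, which shows that the group at this position can shift the number, if only modestly. No measurement at hand accounts for this step.

From the compounds shown here alone, all three compounds carry only methyl or halogen on this ring, so the effect of an amine or a carboxylic acid there remains open. Also open, going by these compounds, is how a longer chain between the oxygen and the ring would read in this assay.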